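A few compounds are considered here, and "the series" means these few. Any claim that something is new, unique, unknown or untested is made for them only; others in the source may bear on it.

Measured so far:
compound 1, `CCOC(=O)C1=C(C)NC(C)=C(C(=O)OCC)C1c1ccc(OCC(=O)Nc2ccc(C)cc2)cc1`: 43.9%
compound 2, `CCOC(=O)C1=C(C)NC(C)=C(C(=O)OCC)C1c1ccc(OCC(=O)NNC(=O)c2sccc2Cl)cc1`: 10.6%

Both were run in a functional assay on the whole organism (strain Wistar) for inhibition, with Rattus norvegicus as the target, read by paw edema, with stated times of 30 min and 0.5 h, at a dose of 20 mg/kg; on this read-out higher numbers stand for more inhibition at the one dose given (going by the name of the read-out) and lower numbers for less inhibition. Compound 2 stands lowest of the two numbers; its nearest neighbour is compound 1, and the step of a number 33.3 percentage points lower from compound 1 to compound 2 (beyond the scatter) lies beyond the scatter.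

Compound 3, `CCOC(=O)C1=C(C)NC(C)=C(C(=O)OCC)C1c1ccc(OCC(=O)NNC(=O)c2cccs2)cc1`, is not yet measured. It differs from compound 2 by hydrogen in place of chloro on an aromatic carbon, two ring bonds from the ring sulfur. Going by the values given here, no measured step bears on this change: the one step known, a number 33.3 percentage points lower from compound 1 to compound 2 (beyond the scatter), exchanges the whole group on the amide-type nitrogen and says nothing about the chloro alone. Among the compounds with values here, with no step to lean on, no change beyond the scatter is expected, and the step of a number 1.4 percentage points higher from compound 2 to compound 3 (within the scatter) is estimated to be small. Compound 3 is therefore expected to give about 12%, with a range from 2% to 26%.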

Compound 3, a percentage reported as inhibition, in the whole organism at one dose (the size of the read-out at that dose, not a potency): 44%
Compound 3: middle estimate off by 32 percentage points, on the low side; the measured number lies above the stated range.
By their numbers in this assay, from the lowest: compound 2; then compounds 1 and 3 (each within the scatter of the next).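

In this assay, exchanging chloro for hydrogen on the aromatic carbon two ring bonds from the ring sulfur, with all else unchanged, gives a number 33.4 percentage points higher from compound 2 to compound 3 (beyond the scatter). The earlier step exchanged the whole group on the amide-type nitrogen and could not separate the chloro from the rest; now a number 0.1 percentage points higher from compound 1 to compound 3 (within the scatter) places the ((thiophen-2-yl)carbonyl)amino group within the scatter of the 4-methylphenyl group, so the low number of compound 2 goes with the chloro, not with the ((thiophen-2-yl)carbonyl)amino group as such. Nothing available explains why this single atom matters so much.

Going by these compounds, whether this holds for chloro alone stays open: a methyl, bromo or methoxy group on the same carbon would test that. Also open, on these data alone, is how a chloro on another carbon of the thiophen-2-yl ring would read.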